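From Phenethylsulfanyl to Propylsulfanyl on a Shared Core

A few compounds are considered here, and "the series" means these few. Any claim that something is new, unique, unknown or untested is made for them only; others in the source may bear on it.

Going by the values given here, in a functional assay on HGC-27 cells (Homo sapiens) for inhibition, read by MTT assay, with a stated time of 72 h (a higher number here means a weaker inhibitor, a lower number a stronger inhibitor), compound 1 `Cc1cc(N2CC[C@@H](C)[C@@H](N(C)c3ncnc4[nH]ccc34)C2)n2nc(SCCc3ccccc3)nc2n1` gives 11800 nM, the only actual number in this small set. Compound 2 `CCCCCc1c(C)nc2nc(SCc3ccc(Cl)cc3)nn2c1N1CC[C@@H](C)[C@@H](N(C)c2ncnc3[nH]ccc23)C1` is reported only as a limit, > 100000 nM. Compound 3 `CCc1cc(N2CC[C@@H](C)[C@@H](N(C)c3ncnc4[nH]ccc34)C2)n2ncnc2n1` is likewise reported only as a limit, > 100000 nM. The evidence is therefore thin, with the limit of > 100000 nM in this assay, at which 2 of the 3 values shown sit.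

Compound 4 `CCCSc1nc2nc(C)cc(N3CC[C@@H](C)[C@@H](N(C)c4ncnc5[nH]ccc45)C3)n2n1` carries propylsulfanyl where compound 1 carries phenethylsulfanyl, which amounts to methyl in place of phenyl on a saturated chain carbon, two bonds along the chain from a sulfur. Among the compounds with values here, no measured pair shows what this change does. In this assay, a weakening beyond the usual scatter is nevertheless expected, resting on compound 1 at 11800 nM being the only one of the three to give a number. The estimated change is a 3.0-fold higher number from compound 1 to compound 4 (0.47 log units; beyond the scatter), towards weaker inhibition, and a result reported only as a limit would not be surprising. Compound 4 is estimated at 35000 nM, with an expected range of 14000 nM to 100000 nM.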

Compound 4, half-maximal inhibitory concentration: 20900 nM
Beside the measured number, compound 4's estimate is 1.7-fold (0.22 log units) above it; the measured number falls inside the stated range.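

In this assay, the change from phenethylsulfanyl to propylsulfanyl gives a 1.8-fold higher number from compound 1 to compound 4 (0.25 log units; within the scatter), so the two compounds cannot be told apart at this position. Going by these compounds alone, this is the first measured pair in the set, and it shows that the phenyl at the end of the chain is not required for the compound to give a number, since methyl in its place also gives one. The other two compounds still offer no number for comparison: the limit of > 100000 nM in this assay, at which 2 of the 4 values shown sit.

Going by these compounds, what an amine or a carboxylic acid at the end of this chain would do remains open, as does the effect of a longer chain without a ring. On these data alone, whether an ether oxygen in place of the sulfur would give a similar reading is equally open.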